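The source may hold more compounds than are shown below. What is called first, only, known or untested is meant among the compounds shown, and "the series" means these compounds.

Compounds measured in an in vitro assay on HEK385-7 cells for displacement of a labelled ligand from prostaglandin D2 receptor 2 (Homo sapiens); a lower number here means a stronger inhibitor, a higher number a weaker inhibitor:
compound 1 `CS(=O)(=O)Nc1cccc(-c2nc(C(c3ccc(F)cc3)c3ccc(F)cc3)sc2CC(=O)O)c1`: 40 nM
compound 2 `O=C(O)Cc1sc(C(c2ccc(F)cc2)c2ccc(F)cc2)nc1-c1ccnc(Cl)c1`: 3.1 nM
compound 3 `O=C(O)Cc1sc(C(c2ccc(F)cc2)c2ccc(F)cc2)nc1-c1cc(F)nc(F)c1`: 5.4 nM

Compound 3 stands second among these three numbers. Its nearest neighbour is compound 2, and the difference between them, a 1.7-fold higher number from compound 2 to compound 3 (0.24 log units; within the scatter), lies within the scatter of the method. Its furthest neighbour is compound 1, from which it is separated by a 7.4-fold lower number from compound 1 to compound 3 (0.87 log units; beyond the scatter); the parallel move to compound 2 gave a 13-fold lower number from compound 1 to compound 2 (1.11 log units; beyond the scatter). Both of those steps replaced the 3-(methanesulfonamido)phenyl group with a substituted pyridin-4-yl group, and both lowered the number clearly.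

Compound 4 `O=C(O)Cc1sc(C(c2ccc(F)cc2)c2ccc(F)cc2)nc1-c1ccnc(N2CCC2)c1` has not yet been measured. It differs from compound 3 in one place: 2-(azetidin-1-yl)pyridin-4-yl in place of 2,6-difluoropyridin-4-yl on an aromatic carbon. Among the compounds with values here, the only measured step that bears directly on this kind of change is the exchange of one substituent pattern on the pyridin-4-yl ring for another, from compound 2 to compound 3, which stayed within the scatter. Within the data shown here, no measured compound carries an azetidin-1-yl group, so nothing shows how that group behaves here. On this basis the number for compound 4 is expected to stay close to that of compound 3, with a 1.5-fold higher number from compound 3 to compound 4 (0.17 log units; within the scatter) as the estimated step, and no change beyond the scatter is foreseen. The estimate for compound 4 in this assay is 8 nM, with a range from 2.5 nM to 30 nM.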

Compound 4, half-maximal inhibitory concentration: 660 nM
For compound 4 the middle estimate is 83-fold (1.92 log units) below the measured one, and the stated range ends below it.
By their numbers in this assay, from the lowest: compounds 2 and 3 (each within the scatter of the next); then compound 1; then compound 4.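

In this assay, the substituent on the pyridin-4-yl ring decides the result, and not every exchange there is as harmless as the change between the two halogen-bearing compounds. The change to 2-(azetidin-1-yl)pyridin-4-yl gave a 120-fold higher number from compound 3 to compound 4 (2.09 log units; beyond the scatter), and azetidin-1-yl in place of chloro gave a 210-fold higher number from compound 2 to compound 4 (2.33 log units; beyond the scatter). The pyridin-4-yl ring alone therefore does not secure the lower numbers, since the exchange of the 3-(methanesulfonamido)phenyl group for the azetidin-1-yl-bearing ring gave a 17-fold higher number from compound 1 to compound 4 (1.22 log units; beyond the scatter), the opposite direction from compounds 2 and 3, and no experimental evidence is available to explain this reversal.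

The compounds shown leave open whether the higher number belongs to the azetidin-1-yl ring specifically or to nitrogen-linked substituents at this place more generally, which a plain amino group, a dimethylamino group or a pyrrolidin-1-yl ring could separate. They also leave open how a small carbon- or oxygen-linked substituent, such as methyl or methoxy, would behave in place of the chloro of compound 2.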